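Compound 1 and the Step to Compound 3

The source may hold more compounds than are shown below. What is called first, only, known or untested is meant among the compounds shown, and "the series" means these compounds.

Measured so far in a functional assay on SK-BR-3 cells (Homo sapiens) for antiproliferative activity; a lower number here means a stronger inhibitor, a higher number a weaker inhibitor (lower means stronger):
compound 1 (`CCCCOc1ccc(C(=O)Nc2cc3ccc(OC4CCN(C)CC4)c(C)c3oc2=O)cc1CC=C(C)C`) gives 1400 nM (half-maximal inhibitory concentration)
compound 2 (`Cc1c(OC2CCN(C)CC2)ccc2cc(NC(=O)c3ccc4c(c3)CCC(C)(C)O4)c(=O)oc12`) gives 3460 nM (half-maximal inhibitory concentration)

Compound 1 has the lower number of the two, and its gap to compound 2 lies beyond the usual scatter. Compound 3 (`CC(C)=CCc1cc(C(=O)Nc2cc3ccc(OC4CCN(C)CC4)c(C)c3oc2=O)ccc1OC1CCN(C)CC1`) keeps the core of compound 1 but has 1-methylpiperidin-4-yl in place of butyl on an oxygen on an aromatic ring. Going by the values given here, no measured pair shows this change, so the expectation is uncertain. What is expected is a 2.1-fold higher number from compound 1 to compound 3 (0.33 log units; beyond the scatter) in this assay (a modest move toward weaker inhibition). For compound 3 the estimated value is 3000 nM (expected range 700 nM to 12000 nM).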

Compound 3, half-maximal inhibitory concentration: 210 nM
The estimate for compound 3 lay 14-fold (1.15 log units) above the measured number; measured number below the stated range.
By their numbers in this assay, from the lowest: compound 3; then compound 1; then compound 2.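

Going by these compounds alone, replacing butyl with 1-methylpiperidin-4-yl on this oxygen gives a 6.7-fold lower number from compound 1 to compound 3 (0.82 log units; beyond the scatter) in this assay, the first sign that the group on this oxygen affects the result. A larger group containing a ring and a nitrogen is therefore compatible with stronger inhibition here. No measurement shown explains the change. The compounds shown leave open whether the ring or the nitrogen matters more. Cyclohexyl, which has the ring without the nitrogen, and 2-(dimethylamino)ethyl, which has an amine without the ring, would separate these two features.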